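The source may hold more compounds than are shown below. What is called first, only, known or untested is meant among the compounds shown, and "the series" means these compounds.

Compound 1 `Cc1ccc2[nH]c(=O)c(-c3nc4ccccc4[nH]3)cc2c1` and compound 2 `Cc1ccc2[nH]c(=O)c(-c3nc4cc(F)ccc4[nH]3)cc2c1` share one core and differ by fluoro in place of hydrogen on an aromatic carbon. In a functional assay on HepG2 cells (Homo sapiens) for cytotoxicity, read by MTT assay, with a stated time of 48 h (a higher number here means a weaker inhibitor, a lower number a stronger inhibitor), compound 1 gives only a limit, > 100000 nM. In this assay compound 2 likewise gives only a limit, > 100000 nM. The step that the two limits leave unreadable from compound 1 to compound 2 is therefore of unreadable size, as both values sit at the limit of > 100000 nM in this assay, at which 2 of the 2 values shown sit. Compound 3 `Cc1ccc2[nH]c(=O)c(-c3nc4cc(Cl)ccc4[nH]3)cc2c1` differs from compound 2 in that (chloro in place of fluoro on an aromatic carbon). Among the measured compounds shown here, only this one measured step exists, and it gives no readable size, so no measured step says how large the change from fluoro to chloro should be in this assay. With compound 2 at a limit, compound 3 is expected to show no step beyond the scatter, estimated as a step that the limit leaves unreadable from compound 2 to compound 3. Compound 3 is accordingly estimated to give about 150000 nM, within 60000 nM to 400000 nM, most likely again reported only as a limit.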

Compound 3, half-maximal inhibitory concentration: 26600 nM
The estimate for compound 3 lay 5.6-fold (0.75 log units) above the measured number; the whole stated range lies above it.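

In this assay, among the compounds shown here, this position proves able to change the read-out: chloro in place of fluoro on the aromatic carbon gives an at least 3.7-fold lower number from compound 2 to compound 3 (0.57 log units; beyond the scatter), the first readable step. Chloro in place of hydrogen on the same carbon gives an at least 3.7-fold lower number from compound 1 to compound 3 (0.57 log units; beyond the scatter), so compound 3 is set apart from both of the other compounds, while the step between those two cannot be read. Both readable steps are only lower bounds on the true size, as each starts from a limit and not from a number: the limit of > 100000 nM in this assay, at which 2 of the 3 values shown sit.

On these data alone, the true size of these steps therefore remains open. Also open, as far as these compounds go, is how bromo, methyl, methoxy or an amine on this carbon would read, and whether chloro on another carbon of the shared core would give a similar step.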